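A step that starts without a number

A few compounds are considered here, and "the series" means these few. Any claim that something is new, unique, unknown or untested is made for them only; others in the source may bear on it.

- Compound 1 `Cc1ccc(S(=O)(=O)c2nc3ccccc3nc2Nc2ccc(C(F)(F)F)cc2)cc1`: 10300 nM
- Compound 2 `COc1ccc(S(=O)(=O)c2nc3ccccc3nc2Nc2cc(OC)cc(OC)c2)cc1`: "not determined" (no result reported)

In a functional assay on KB cells (Homo sapiens) for cytotoxicity, read by MTT assay, with a stated time of 72 h (on this read-out higher numbers stand for weaker inhibition and lower numbers for stronger inhibition), compound 2 stands at "not determined" (no result reported), so it gives no number to start from. Compound 3 `COc1ccc(S(=O)(=O)c2nc3ccccc3nc2Nc2ccc(C(F)(F)F)cc2)cc1` is still unmeasured. The structural change is 4-(trifluoromethyl)phenyl in place of 3,5-dimethoxyphenyl on a nitrogen on an aromatic ring. Without a starting value, no direction can be expected, and the working expectation is a step no larger than the usual scatter. Among the measured compounds shown here, the only anchor is compound 1, which also carries 4-(trifluoromethyl)phenyl and gives 10300 nM. For compound 3, the estimated value is 9000 nM, with an expected range of 3500 nM to 25000 nM.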

Compound 3, half-maximal inhibitory concentration: 890 nM
Beside the measured number, compound 3's estimate is 10-fold (1.00 log units) above it; measured number outside the range, below it.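

With the 4-(trifluoromethyl)phenyl group held fixed, methoxy in place of methyl on an aromatic carbon gives a 12-fold lower number from compound 1 to compound 3 (1.06 log units; beyond the scatter) in this assay, so this single small swap clearly changes the result. The change from 3,5-dimethoxyphenyl to 4-(trifluoromethyl)phenyl on the nitrogen cannot be read, since compound 2 has no number. Nothing measured here explains the difference. From the compounds shown here alone, whether an ethoxy group or an amine on that same carbon would lower the number further stays open, as does how much the group on the nitrogen contributes.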